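The compounds below may be only part of what the source reports. "The series", "measured", "known", "first", "only" and "open" are said of these compounds alone.

Working notes on the cytotoxicity series.

Of the compounds shown here, two have numbers so far. Compound 1 `COc1ccc(F)cc1CNCCCNc1ccnc2cc(Cc3ccccc3)ccc12` gives in an ADME assay on HepG2 cells (Homo sapiens) for cytotoxicity, read by luminescence, CellTiter-Glo and ATP content, with a stated time of 72 h (on this read-out higher numbers stand for an effect only at larger amounts of compound and lower numbers for an effect already at smaller amounts), a value of 7990 nM. Compound 2 `COc1ccc(F)cc1CNCCCNc1ccnc2cc(-c3cccc4ccccc34)ccc12` gives in this assay 16000 nM. For the measured compounds named here, the single step between them, a 2.0-fold higher number from compound 1 to compound 2 (0.30 log units; within the scatter), is the only one measured. On the numbers shown, compound 2 holds the highest value of the two, with compound 1 as its only neighbour, and the gap between them does not exceed the scatter, so no order between the two can be claimed.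

Compound 3 `COc1ccc(F)cc1CNCCCNc1ccnc2cc(Oc3ccccc3OC)ccc12` is not yet measured. Relative to compound 2 the change is 2-methoxyphenoxy in place of naphthalen-1-yl on an aromatic carbon. Going by the values given here, no measured step touches this change: the one step on record, from a benzyl group to a naphthalen-1-yl group, concerns a different pair of groups at the same aromatic carbon and was itself within the scatter. With nothing to anchor a direction, the expected step of a 1.1-fold lower number from compound 2 to compound 3 (0.03 log units; within the scatter) is none beyond the scatter, and the expectation carries a wide range. Compound 3 is therefore estimated at 15000 nM in this assay, between 6000 nM and 40000 nM.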

Compound 3, half-maximal effective concentration: 6400 nM
Compound 3: middle estimate off by 2.3-fold (0.37 log units), on the high side; the range from low to high includes it.
By their numbers in this assay, from the lowest: compounds 3, 1 and 2 (each within the scatter of the next, the first and the last beyond it).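

At this aromatic carbon, meta to a fused ring and para to a fused ring, this assay now shows its first step beyond the scatter, a modest one: a 2.5-fold lower number from compound 2 to compound 3 (0.40 log units; beyond the scatter) with 2-methoxyphenoxy in place of naphthalen-1-yl. For the compounds shown here, the same group set against benzyl gives a 1.2-fold lower number from compound 1 to compound 3 (0.10 log units; within the scatter) and stays within the scatter, so only the pair with naphthalen-1-yl is separated, and compound 1 cannot be ordered against either of the others. The exchange replaces two six-membered aromatic rings of carbon only with one such ring and brings in two hydrogen-bond acceptors, but no measurement at hand ties the step to either difference or explains it.

The compounds shown leave open whether the step belongs to the oxygen link or to the methoxy group, a question that an unsubstituted phenoxy group at this carbon would address. Also open, as far as these compounds go, is how this assay responds to an amine or a carboxylic acid at this carbon, and whether the step holds with a different chain on the shared core.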